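This account rests on a few compounds, and the source may have more. Where it says the series, first, only, none or still open, it means among the compounds named here.

In an ADME assay on HOS cells (Homo sapiens) for cytotoxicity (on this read-out lower numbers stand for higher toxicity in this test and higher numbers for lower toxicity in this test), compound 1 `CN(Cc1nc2cccc(CN)c2[nH]1)C1CCCc2cccnc21` gives > 20000 nM, which is a limit of the assay. Compound 2 `CN(Cc1nc2cccc(CCCN3CCCCC3)c2[nH]1)C1CCCc2cccnc21` gives a real number, 8700 nM. Compound 3 `CN(Cc1nc2cccc(N3CCN(C(=O)OC(C)(C)C)CC3)c2[nH]1)C1CCCc2cccnc21` gives > 10000 nM, which is also a limit, so its true position is not known. Compound 4 `CN(Cc1nc2cccc(N3CCNCC3)c2[nH]1)C1CCCc2cccnc21` differs from it as follows: hydrogen in place of tert-butoxycarbonyl on an amine nitrogen in a ring. In words, hydrogen stands in place of tert-butoxycarbonyl on an amine nitrogen in a ring. Within the data shown here, only one measured step bears on this, and only loosely, since it changes another group: an at least 2.2-fold lower number from compound 1 to compound 2 (0.36 log units; beyond the scatter). That step is modest, so no large change is expected here. The estimated step is a step that the limit leaves unreadable from compound 3 to compound 4, and it is not expected to clearly exceed the scatter. Compound 4 is expected at 15000 nM, within an estimated range of 6000 nM to 35000 nM.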

Compound 4, half-maximal cytotoxic concentration: > 20000 nM
Compound 4 was reported as a limit; the forecaster's own chance of this, stated with the estimate: 55%; middle value at least 1.3-fold (0.12 log units) away from the limit.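

In this assay, compound 4 sits at a limit, as a bare ring nitrogen without the tert-butoxycarbonyl: the limit of > 20000 nM in this assay, at which 2 of the 4 values shown sit.
Piperazin-1-yl in place of 3-(piperidin-1-yl)propyl gives an at least 2.2-fold higher number from compound 2 to compound 4 (0.36 log units; beyond the scatter), so the piperazine sits on the lower-toxicity side in this test. The steps to compound 4 from compound 3 and from compound 1 join two limits and cannot be read.

Going by these compounds, only compound 2 has a real number here, so the true size of these differences stays unknown. On these data alone, whether a methyl or an acetyl on that ring nitrogen would give a real number remains open.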